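Amide aryl swap repeated on the second core

This account rests on a few compounds, and the source may have more. Where it says the series, first, only, none or still open, it means among the compounds named here.

Measured so far in a functional assay on MDA-MB-231 cells (Homo sapiens) for cytotoxicity, read by MTT assay, with a stated time of 72 h; a lower number here means a stronger inhibitor, a higher number a weaker inhibitor:

Compound 1, `O=C(CN1CCN(c2nnc(Cc3ccccc3)c3ccccc23)CC1)Nc1c(F)cccc1F`, gives 5490 nM.
Compound 2, `Cc1ccccc1NC(=O)CN1CCN(c2nnc(Cc3ccccc3)c3ccccc23)CC1`, gives 17300 nM.
Compound 3, `O=C(CN1CCN(c2nnc(Cc3ccncc3)c3ccccc23)CC1)Nc1c(F)cccc1F`, gives 1900 nM.

The change 2-methylphenyl in place of 2,6-difluorophenyl on an amide-type nitrogen has been measured once, on the core of compound 1: it made the step of a 3.2-fold higher number from compound 1 to compound 2 (0.50 log units; beyond the scatter) in this assay, a weakening beyond the scatter. The two cores differ by pyridin-4-yl in place of phenyl on a saturated chain carbon bound to an aromatic carbon, and that single change gave a 2.9-fold lower number from compound 1 to compound 3 (0.46 log units; beyond the scatter), so compound 3 stands lowest of the three measured numbers, with both of its steps to the others beyond the scatter.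

Compound 4, `Cc1ccccc1NC(=O)CN1CCN(c2nnc(Cc3ccncc3)c3ccccc23)CC1`, is not yet measured. It differs from compound 3 by 2-methylphenyl in place of 2,6-difluorophenyl on an amide-type nitrogen. Going by the values given here, the place of this change, an amide-type nitrogen whose other neighbour is the carbonyl carbon, reads the same word for word on both cores, so this is the same change as the one from compound 1 to compound 2, made the second time. With only one earlier occurrence there is no way to tell whether the swap behaves alike on the two cores; the expectation simply carries the measured step over.

For compound 4 the step of a 3.2-fold higher number from compound 3 to compound 4 (0.50 log units; beyond the scatter) is expected in this assay, resting on the earlier step of a 3.2-fold higher number from compound 1 to compound 2 (0.50 log units; beyond the scatter) applied to the value of compound 3. Compound 4 is therefore estimated at 6000 nM, with the likely range expected to run from 2500 nM to 15000 nM.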

Compound 4, half-maximal inhibitory concentration: 200 nM
Beside the measured number, compound 4's estimate is 30-fold (1.48 log units) above it, and the stated range ends above it.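

On the core of compound 3, 2-methylphenyl in place of 2,6-difluorophenyl gives a 9.5-fold lower number from compound 3 to compound 4 (0.98 log units; beyond the scatter) in this assay, so the swap runs opposite to its direction on the core of compound 1: the same change on two cores in this assay, a 3.2-fold higher number (0.50 log units; beyond the scatter) from compound 1 to compound 2 and a 9.5-fold lower number (0.98 log units; beyond the scatter) from compound 3 to compound 4, 30-fold (1.48 log units) apart, beyond the scatter of two such steps

Read the other way round, pyridin-4-yl in place of phenyl gives an 87-fold lower number from compound 2 to compound 4 (1.94 log units; beyond the scatter) with the 2-methylphenyl amide, so its size depends on the group on the amide nitrogen: the same change on two cores in this assay, a 2.9-fold lower number (0.46 log units; beyond the scatter) from compound 1 to compound 3 and an 87-fold lower number (1.94 log units; beyond the scatter) from compound 2 to compound 4, 30-fold (1.48 log units) apart, beyond the scatter of two such steps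

Across these four compounds, neither step carries over from one core to the other, and the two changes do not act independently; this rests on a single set of four compounds, however, and does not show why the two places are coupled or whether the coupling extends to any other pair of groups.

On these data alone, it remains open whether the reversal also appears with other groups on the amide nitrogen, such as unsubstituted phenyl, a chlorophenyl or cyclohexyl, or with a group other than phenyl or pyridin-4-yl on the saturated chain carbon, such as an aminophenyl. As far as these compounds go, whether the same coupling holds on any read-out other than this assay is also open.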